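This account rests on a few compounds, and the source may have more. Where it says the series, first, only, none or still open, it means among the compounds named here.

Working notes, cytotoxicity series. Of the compounds shown here, two carry numbers so far in a functional assay on OVCAR-5 cells (Homo sapiens) for cytotoxicity, read by sulforhodamine B assay, with a stated time of 48 h, tested at 10 uM; on this read-out lower numbers stand for a stronger effect and higher numbers for a weaker effect at the one concentration tested. Compound 1 `Cc1cc(O)cc(-c2nn(CC#N)cc2-c2ccnc(-c3ccc(Oc4ccccc4)cc3)c2)c1` gives -89%. Compound 2 `COc1cc(C)cc(-c2nn(CC#N)cc2-c2ccnc(-c3ccc(N(C)C)cc3)c2)c1` gives 15%, the highest of the two numbers; the nearest number, that of compound 1, stands lower by more than the scatter. Among the compounds with values here, no step between measured compounds that differ in one place is available, so the two values show only that compound 1 and compound 2 lie far apart in this assay.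

Compound 3 `Cc1cc(O)cc(-c2nn(CC#N)cc2-c2ccnc(-c3ccc(N(C)C)cc3)c2)c1` is not yet measured. It differs from compound 2 in one place: hydrogen in place of methyl on an oxygen on an aromatic ring. Compound 1 also carries the 3-hydroxy-5-methylphenyl group, but its other aryl group differs from that of compound 2, so its value cannot be read as a step for this change.

The step of a number 45 percentage points lower from compound 2 to compound 3 (beyond the scatter) is expected to go downward, beyond the scatter. The estimate for compound 3 in this assay is -30%, with a range from -90% to 20%.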

Compound 3, a percentage reported as activity, at one concentration (the size of the read-out at that concentration, not a potency): -18%
For compound 3 the middle estimate is 12 percentage points below the measured one; low and high end bracket the measured number.
By their numbers in this assay, from the lowest: compound 1; then compound 3; then compound 2.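

Hydrogen in place of methyl on an oxygen on an aromatic ring now has a reading of its own in this assay: with the dimethylamino group held fixed, the series shows a number 33 percentage points lower from compound 2 to compound 3 (beyond the scatter). With the 3-hydroxy-5-methylphenyl group held fixed, dimethylamino in place of phenoxy on an aromatic carbon gives a number 71 percentage points higher from compound 1 to compound 3 (beyond the scatter), so the second aryl position also has a single-place step. Nothing available on these compounds accounts for either step.

The compounds shown leave open whether the change from methoxy to hydroxy gives a step of similar size when phenoxy is present. They also do not show how an ethyl group or a longer chain on that oxygen, or an amine in place of the hydroxy, would read in this series.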